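Dropping the Chloro Group from Compound 1

The source may hold more compounds than are shown below. What is called first, only, known or untested is meant among the compounds shown, and "the series" means these compounds.

Compound 1 `Nc1ccc(-c2cc(=O)c3c(N)c(Cl)ccc3o2)cc1`: > 10000 nM
Compound 2 `Nc1ccc(-c2cc(=O)c3c(N)c(F)cc(F)c3o2)cc1F`: 25 nM

Among the measured compounds shown here, both compounds have been tested in a functional assay on MCF7 cells (Homo sapiens) for inhibition, in the presence of a further agent that is not named here; a lower number here means a stronger inhibitor, a higher number a weaker inhibitor. Compound 1 returns only a limit, > 10000 nM, the edge of what this assay can report rather than a measured number, and this is the limit of > 10000 nM in this assay, at which 1 of the 2 values shown sits. Compound 2, a differently substituted analogue, reaches 25 nM in this assay, so the two values show that compound 2 is the stronger inhibitor and compound 1 the weaker.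

Compound 3 `Nc1ccc(-c2cc(=O)c3c(N)cccc3o2)cc1` has not yet been tested. It differs from compound 1 in one place: hydrogen in place of chloro on an aromatic carbon. For the measured compounds named here, no measured pair shows this change on its own, so its effect in this assay is open. Because compound 1 sits at the limit of > 10000 nM in this assay, at which 1 of the 2 values shown sits, the step can hardly make compound 3 weaker in any visible way; a gain is possible, but compound 2 shows that a potent member of this series carries other groups. Compound 3 is therefore expected to land at about 5000 nM, in a range from 500 nM to 30000 nM. The expected step of an at least 2.0-fold lower number from compound 1 to compound 3 (0.30 log units; that floor lies within the scatter) is a modest improvement that may still leave compound 3 near the limit.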

Compound 3, half-maximal inhibitory concentration: 210 nM
Compound 3: middle estimate off by 24-fold (1.38 log units), on the high side; the measured number lies below the stated range.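

In this assay, hydrogen in place of chloro on an aromatic carbon, ortho to an amino group, gives an at least 47-fold lower number from compound 1 to compound 3 (1.67 log units; beyond the scatter). This shows that a single atom at this position of the shared core is enough to separate a compound stuck at the edge of the assay from one with a real measured potency, so this position is far from a silent one. The step has no upper end, and its true size could be larger, because compound 1 stands at a limit of the assay and not at a number: the limit of > 10000 nM in this assay, at which 1 of the 3 values shown sits.

The compounds shown compare only chloro and hydrogen on this carbon, so it stays open whether any group placed there costs inhibition or chloro alone does, and the data give no reason for the loss. From the compounds shown here alone, a methyl or a methoxy group on the same carbon would help to tell these readings apart, and it also remains open whether the same change would have a similar effect on a core that carries other groups.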